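Compound 2 to compound 3: carbamoyl for 4-nitrophenyl

The source may hold more compounds than are shown below. What is called first, only, known or untested is meant among the compounds shown, and "the series" means these compounds.

In a functional assay on MCF7 cells (Homo sapiens) for cytotoxicity, read by sulforhodamine B assay, with a stated time of 48 h (on this read-out higher numbers stand for weaker inhibition of growth and lower numbers for stronger inhibition of growth), compound 1 (`COc1ccc(N/N=C/c2c(C)nn(-c3ccccc3)c2Oc2ccc(-c3nc4cc(C(N)=O)ccc4[nH]3)cc2)cc1`) gives 13600 nM and compound 2 (`Cc1nn(-c2ccccc2)c(Oc2ccc(-c3nc4cc(C(N)=O)ccc4[nH]3)cc2)c1/C=N/Nc1ccc([N+](=O)[O-])cc1`) gives 8500 nM, so compound 2 stands within the scatter of compound 1. Compound 3 (`Cc1nn(-c2ccccc2)c(Oc2ccc(-c3nc4cc(C(N)=O)ccc4[nH]3)cc2)c1/C=N/NC(N)=O`) differs from compound 2 as follows: carbamoyl in place of 4-nitrophenyl on an amine nitrogen. For the measured compounds named here, the only measured step, a 1.6-fold lower number from compound 1 to compound 2 (0.20 log units; within the scatter), exchanged methoxy for nitro on an aromatic carbon and offers weak guidance. Going by the values given here, no measured step replaces the whole 4-nitrophenyl, so no change beyond the scatter is expected in this assay. The expected change is a 1.1-fold higher number from compound 2 to compound 3 (0.02 log units; within the scatter). For compound 3 the estimate is 9000 nM, with an expected range of 3500 nM to 25000 nM.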

Compound 3, concentration for 50% growth inhibition: 6500 nM
Beside the measured number, compound 3's estimate is 1.4-fold (0.14 log units) above it, and the stated range covers the measured number.
By their numbers in this assay, from the lowest: compounds 3, 2 and 1 (each within the scatter of the next, the first and the last beyond it).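

In this assay, an aromatic ring on this amine nitrogen is not required across the compounds shown, since the much smaller, ring-free carbamoyl group replaces it without loss. Replacing 4-nitrophenyl gives a 1.3-fold lower number from compound 2 to compound 3 (0.12 log units; within the scatter), while replacing 4-methoxyphenyl gives a 2.1-fold lower number from compound 1 to compound 3 (0.32 log units; beyond the scatter), so the gain depends on which aryl group is the reference. Nothing available explains these differences. On these data alone, whether an acetyl group, a methyl group or a thiocarbamoyl group on this nitrogen would read similarly remains open. As far as these compounds go, a 4-aminophenyl group also remains untested against this comparison.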